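Aryl amide variation on a cytotoxic arylidene core

The source may hold more compounds than are shown below. What is called first, only, known or untested is meant among the compounds shown, and "the series" means these compounds.

Three analogues sharing one core were tested in an ADME assay on SW480 cells (Homo sapiens) for cytotoxicity, read by MTT assay, with a stated time of 72 h; on this read-out lower numbers stand for stronger inhibition and higher numbers for weaker inhibition. Compound 1 `CCc1cccc(NC(=O)c2cccc(/C=C3\CC(=O)N(c4ccccc4)C3=O)c2)c1` gives 88600 nM. For compound 2 `O=C(NCC1CCCCC1)c1cccc(/C=C2\CC(=O)N(c3ccccc3)C2=O)c1` the result in this assay is only a limit, > 100000 nM. Compound 3 `CSc1cccc(NC(=O)c2cccc(/C=C3\CC(=O)N(c4ccccc4)C3=O)c2)c1` gives 74300 nM. Among the two numbers shown, compound 3 sits at the lower end, with compound 1 beside it at a 1.2-fold lower number from compound 1 to compound 3 (0.08 log units; within the scatter); the comparison of compound 2 with compound 3 reads an at least 1.3-fold lower number from compound 2 to compound 3 (0.12 log units; that floor lies within the scatter), and that of compound 1 with compound 2 reads an at least 1.1-fold higher number from compound 1 to compound 2 (0.05 log units; that floor lies within the scatter), both resting on a value that is a limit (the limit of > 100000 nM in this assay, at which 1 of the 3 values shown sits).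

Compound 4 `CCOc1ccc(NC(=O)c2cccc(/C=C3\CC(=O)N(c4ccccc4)C3=O)c2)cc1` differs from compound 3 as follows: 4-ethoxyphenyl in place of 3-(methylsulfanyl)phenyl on an amide-type nitrogen. Going by the values given here, the steps that bear on this change, replacing one aromatic substituent and swapping the group on the amide-type nitrogen, all stayed within the scatter, so no step beyond the scatter is expected in this assay. Compound 4 is therefore estimated at 90000 nM, within 40000 nM to 200000 nM, an expected step of a 1.2-fold higher number from compound 3 to compound 4 (0.08 log units; within the scatter).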

Compound 4, half-maximal inhibitory concentration: 91500 nM
Compound 4: middle estimate off by 1.0-fold (0.01 log units), on the low side, and the stated range covers the measured number.
By their numbers in this assay, from the lowest: compounds 3, 1 and 4 (each within the scatter of the next). At a limit, above all of these: compound 2.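

On the amide-type nitrogen, 4-ethoxyphenyl is the only group shown that carries an oxygen, and it leaves the read-out where the sulfur and carbon substituents had it: replacing 3-(methylsulfanyl)phenyl gives (a 1.2-fold higher number from compound 3 to compound 4 (0.09 log units; within the scatter)), and replacing 3-ethylphenyl gives (a 1.0-fold higher number from compound 1 to compound 4 (0.01 log units; within the scatter)). Among compound 1, compound 3 and compound 4, then, neither the change of substituent nor the change from a 3-substituted name to a 4-substituted one separates the values. The comparison with the cyclohexylmethyl amide, (an at least 1.0-fold lower number from compound 2 to compound 4 (0.03 log units; that floor lies within the scatter)), gives only a floor, and compound 2 remains a limit: the limit of > 100000 nM in this assay, at which 1 of the 4 values shown sits.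

From the compounds shown here alone, whether an amine or a carboxylic acid in place of the ethoxy group would move the value beyond the scatter remains open. So does whether a change elsewhere on the shared core would do so.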